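Fluoro for Bromo on the Aryl Ring of Compound 2

A few compounds are considered here, and "the series" means these few. Any claim that something is new, unique, unknown or untested is made for them only; others in the source may bear on it.

Three compounds share one core: compound 1 `Cc1ccccc1-n1cc(-c2ccccc2)c(-c2ccc3c(c2)NC(=O)CO3)n1`, compound 2 `O=C1COc2ccc(-c3nn(-c4ccc(Br)cc4)cc3-c3ccccc3)cc2N1` and compound 3 `O=C1COc2ccc(-c3[nH]c(-c4c[nH]c5ncccc45)nc3-c3ccccc3)cc2N1`. In a functional assay on A549 cells (Homo sapiens) for cytotoxicity, read by colorimetric assay and MTT assay, with a stated time of 3 days, tested at 20 uM (on this read-out higher numbers stand for a weaker effect at the one concentration tested and lower numbers for a stronger effect), compound 1 gives 85.3%, compound 2 gives 58.8% and compound 3 gives 86.8%, so compound 2 shows the strongest effect of the three, its steps to both others lying beyond the scatter. Within the data shown here, the only measured step, a number 26.5 percentage points lower from compound 1 to compound 2 (beyond the scatter), concerns the same aryl ring that compound 4 `O=C1COc2ccc(-c3nn(-c4ccc(F)cc4)cc3-c3ccccc3)cc2N1` alters: fluoro in place of bromo on an aromatic carbon. Among the measured compounds shown here, no measured step bears directly on a halogen swap, so the direction of the change in this assay is uncertain, and a moderate rise toward a weaker effect is expected. Compound 4 is therefore estimated at 72%, within 52% to 92%, an expected step of a number 13.2 percentage points higher from compound 2 to compound 4 (beyond the scatter).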

Compound 4, a percentage reported as activity, at one concentration (the size of the read-out at that concentration, not a potency): 56.4%
Compound 4: the middle estimate sits 15.6 percentage points above what was measured, and the stated range covers the measured number.
By their numbers in this assay, from the lowest: compounds 4 and 2 (each within the scatter of the next); then compounds 1 and 3 (each within the scatter of the next).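

In this assay the swap of bromo for fluoro amounts to a number 2.4 percentage points lower from compound 2 to compound 4 (within the scatter) so at this place on the ring the two halogens cannot be told apart. The stronger effect relative to the 2-methylphenyl group also holds for 4-fluorophenyl, with a number 28.9 percentage points lower from compound 1 to compound 4 (beyond the scatter) and therefore does not rest on bromine alone. Nothing at hand explains either step.

The compounds shown leave open whether a halogen is needed on this ring at all. From the compounds shown here alone, how an amine, a carboxylic acid or a methoxy group at the same place would read remains unknown.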